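This account rests on a few compounds, and the source may have more. Where it says the series, first, only, none or still open, it means among the compounds named here.

In a functional assay on MCF7 cells (Homo sapiens) for inhibition, read by MTT assay, with a stated time of 72 h (a higher number here means a weaker inhibitor, a lower number a stronger inhibitor), compound 1 `CC(C)[C@H](NC(=O)c1cc(Cl)ccc1OCCN)C(=O)Nc1cc(F)cc(C(F)(F)F)c1` gives > 10000 nM, which is a limit of the assay and not a number. Compound 2 `CC(C)[C@H](NC(=O)c1cc(Cl)ccc1OCCNC(=O)OC(C)(C)C)C(=O)Nc1cc(C(F)(F)F)cc(C(F)(F)F)c1` gives > 10000 nM, which is also a limit. Compound 2 therefore stands at the limit of > 10000 nM in this assay, at which 2 of the 2 values shown sit. Compound 3 `CC(C)[C@H](NC(=O)c1cc(Cl)ccc1OCCN)C(=O)Nc1cc(C(F)(F)F)cc(C(F)(F)F)c1` comes from compound 2 by one change, hydrogen in place of tert-butoxycarbonyl on an amine nitrogen. Compound 1, which also carries a 2-aminoethyl group, stays at the limit of > 10000 nM, so only a small move towards stronger inhibition in this assay is expected, perhaps none. The expected size of the step is an at least 1.2-fold lower number from compound 2 to compound 3 (0.09 log units; that floor lies within the scatter). For compound 3 the estimated value is 8000 nM, with an expected range of 2500 nM to 20000 nM.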

Compound 3, half-maximal inhibitory concentration: 6010 nM
Compound 3: middle estimate off by 1.3-fold (0.12 log units), on the high side; the measured number falls inside the stated range.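

Compound 3 is the only one of the three to give a number rather than a limit in this assay, and hydrogen in place of tert-butoxycarbonyl on the amine nitrogen gives an at least 1.6-fold lower number from compound 2 to compound 3 (0.22 log units; that floor lies within the scatter). With the 2-aminoethyl group kept, trifluoromethyl in place of fluoro on an aromatic carbon gives an at least 1.6-fold lower number from compound 1 to compound 3 (0.22 log units; that floor lies within the scatter). Both steps are floors and not full sizes, as one end of each is a limit: the limit of > 10000 nM in this assay, at which 2 of the 3 values shown sit.

On these data alone, whether a longer chain such as 3-aminopropyl, or an acetyl group on the amine nitrogen, would change the number stays open. As far as these compounds go, the true size of either step also stays open.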